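Methoxy count on the aryl ring and cytotoxicity

This account rests on a few compounds, and the source may have more. Where it says the series, first, only, none or still open, it means among the compounds named here.

Compound 1 `COc1ccc(-c2cc(/C=C/C(=O)c3ccc(N)cc3)[nH]n2)cc1` and compound 2 `COc1cc(-c2cc(/C=C/C(=O)c3ccc(N)cc3)[nH]n2)cc(OC)c1OC` share one core and differ only in the number of methoxy groups on the ring attached to it. In a functional assay on T47D cells (Homo sapiens) for cytotoxicity, read by sulforhodamine B assay, with a stated time of 48 h, tested at 100 uM (a lower number here means a stronger effect, a higher number a weaker effect of the compound at the concentration tested), compound 1 gives -54% and compound 2 gives -47%. Compound 2 stands highest of the two numbers, with compound 1 only a little lower, a gap within the usual scatter of repeated measurements. Compound 3 `COc1ccc(-c2cc(/C=C/C(=O)c3ccc(N)cc3)[nH]n2)cc1OC` has not yet been measured. It differs from compound 2 in one place: hydrogen in place of methoxy on an aromatic carbon. Among the compounds with values here, no step between measured compounds that differ in a single place is available, so the size of this change cannot be read from the two values at hand. The two measured compounds sit within the scatter of each other. No step beyond the scatter is therefore expected. The expected step is a number 3 percentage points lower from compound 2 to compound 3 (within the scatter). Compound 3 is estimated in this assay at -50%, within a range from -65% to -35%.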

Compound 3, a percentage reported as activity, at one concentration (the size of the read-out at that concentration, not a potency): -40%
Beside the measured number, compound 3's estimate is 10 percentage points below it; the range from low to high includes it.
By their numbers in this assay, from the lowest: compounds 1, 2 and 3 (each within the scatter of the next, the first and the last beyond it).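

Removing the methoxy on this aromatic carbon, ortho to a methoxy group and meta to a large group, gives a number 7 percentage points higher from compound 2 to compound 3 (within the scatter) in this assay, so this position shows no readable loss or gain at the single concentration tested. Within the data shown here, the first one-place step beyond the scatter comes from the other methoxy change, methoxy in place of hydrogen on an aromatic carbon, which gives a number 14 percentage points higher from compound 1 to compound 3 (beyond the scatter) and is modest in size, so the effect of methoxy on this ring depends on which aromatic carbon carries it. No measured information accounts for either step.

On these data alone, a hydroxyl group or a chlorine atom on these aromatic carbons remains open, as does an ethoxy group in place of methoxy. Single-concentration read-outs also leave open whether the effect of any of the three compounds would be stronger or weaker at other concentrations.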